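The source may report more compounds than this note shows. Statements on the series, on what has been measured and on what is new or still open speak of the compounds shown alone.

In an ADME assay on MRC5 cells (Homo sapiens) for cytotoxicity, read by fluorescence and resazurin assay, with a stated time of 3 days (on this read-out higher numbers stand for weaker inhibition and lower numbers for stronger inhibition), compound 1 `Cc1cn(C2CCN(Cc3cccc(OC4CCCC4)c3)CC2)c(=O)[nH]c1=O` gives 30300 nM. Compound 2 `Cc1cn(C2CCN(Cc3cccc(Oc4cccc(F)c4)c3)CC2)c(=O)[nH]c1=O` gives > 64000 nM, which is a limit of the assay and not a number. Compound 3 `Cc1cn(C2CCN(Cc3cccc(Oc4ccc(F)c(F)c4)c3)CC2)c(=O)[nH]c1=O` differs from compound 2 by fluoro in place of hydrogen on an aromatic carbon, turning 3-fluorophenoxy into 3,4-difluorophenoxy. Going by the values given here, the only measured step, an at least 2.1-fold higher number from compound 1 to compound 2 (0.32 log units; beyond the scatter), exchanged a whole group and ends at the limit of > 64000 nM in this assay, at which 1 of the 2 values shown sits, so it bears only loosely on this smaller change. The expected step in this assay is a number no higher from compound 2 to compound 3 (the limit leaves the size open), with none beyond the scatter anticipated. The estimate for compound 3 is 64000 nM, with an expected range of 30000 nM to 130000 nM.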

Compound 3, half-maximal inhibitory concentration: > 64000 nM
Compound 3: a limit, no number (the forecaster's own chance of this, stated with the estimate: 65%); the middle value sits exactly at the limit.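

In this assay compound 3 gives > 64000 nM, a limit of the assay and not a number. With fluoro in place of hydrogen, ortho to a fluoro group, the result stays at the limit, and the step from the 3-fluorophenoxy compound cannot be read: the limit of > 64000 nM in this assay, at which 2 of the 3 values shown sit. The 3,4-difluorophenyl group in place of cyclopentyl gives an at least 2.1-fold higher number from compound 1 to compound 3 (0.32 log units; beyond the scatter), so a second aryl group now shows this step.

As far as these compounds go, how far the two fluorinated compounds lie past the limit remains open. Also open, from the compounds shown here alone, is whether a chloro or methoxy group at this position would give a readable number.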